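Fluoro Added to the Methyl-Bearing Core

The source may hold more compounds than are shown below. What is called first, only, known or untested is meant among the compounds shown, and "the series" means these compounds.

Compound 1, `c1ccc(-c2ccc(-c3ccc(-c4nc5ccccc5[nH]4)cc3)cc2)cc1`, gives 100000 nM in a functional assay on HOP-62 cells (Homo sapiens) for inhibition, read by sulforhodamine B assay; on this read-out lower numbers stand for stronger inhibition of growth and higher numbers for weaker inhibition of growth. Compound 2, `Fc1ccc(-c2ccc(-c3ccc(-c4nc5ccccc5[nH]4)cc3)cc2)cc1`, carries fluoro in place of hydrogen on an aromatic carbon and in this assay compound 2 gives 39300 nM; this change made a 2.5-fold lower number from compound 1 to compound 2 (0.41 log units; beyond the scatter). Compound 3, `Cc1ccc2[nH]c(-c3ccc(-c4ccc(-c5ccccc5)cc4)cc3)nc2c1`, differs from compound 1 in its core by methyl in place of hydrogen on an aromatic carbon; in this assay compound 3 gives 39300 nM, a step of a 2.5-fold lower number from compound 1 to compound 3 (0.41 log units; beyond the scatter). Compound 2 and compound 3 lie within the scatter of each other, so no order between them can be read.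

Compound 4, `Cc1ccc2[nH]c(-c3ccc(-c4ccc(-c5ccc(F)cc5)cc4)cc3)nc2c1`, is not yet measured. It differs from compound 3 by fluoro in place of hydrogen on an aromatic carbon, the same change as fluoro in place of hydrogen on an aromatic carbon, here made on the core of compound 3 rather than on the core of compound 1. The step from compound 3 to compound 4 is expected to be a 2.2-fold lower number from compound 3 to compound 4 (0.34 log units; beyond the scatter) because a 2.5-fold lower number from compound 1 to compound 2 (0.41 log units; beyond the scatter) is the only measured occurrence of this change, and its carry-over to a second core is an expectation only. Compound 4 is therefore expected to give about 18000 nM, estimated between 8000 nM and 45000 nM.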

Compound 4, concentration for 50% growth inhibition: 33500 nM
Compound 4: middle estimate off by 1.9-fold (0.27 log units), on the low side; low and high end bracket the measured number.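

In this assay, fluoro in place of hydrogen on the core of compound 3 gives a 1.2-fold lower number from compound 3 to compound 4 (0.07 log units; within the scatter), and methyl in place of hydrogen on the core of compound 2 gives a 1.2-fold lower number from compound 2 to compound 4 (0.07 log units; within the scatter). The fluoro step is beyond the scatter on one core and within it on the other, yet the two steps cannot be told apart, so this pair neither shows that the change carries over nor shows that it is lost on the second core: the same change on two cores in this assay, a 2.5-fold lower number (0.41 log units; beyond the scatter) from compound 1 to compound 2 and a 1.2-fold lower number (0.07 log units; within the scatter) from compound 3 to compound 4, 2.2-fold (0.34 log units) apart, within the scatter of two such steps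

The methyl change reads the same way, and it too rests on a single pair of cores: the same change on two cores in this assay, a 2.5-fold lower number (0.41 log units; beyond the scatter) from compound 1 to compound 3 and a 1.2-fold lower number (0.07 log units; within the scatter) from compound 2 to compound 4, 2.2-fold (0.34 log units) apart, within the scatter of two such steps

The compounds shown leave open whether chloro, methoxy or an amine in place of the fluoro would give a step that clearly exceeds the scatter on both cores. Also open, from the compounds shown here alone, is whether a carboxylic acid or a longer chain in place of the methyl would do so, and whether either change behaves alike in other cell lines.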